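A few compounds are considered here, and "the series" means these few. Any claim that something is new, unique, unknown or untested is made for them only; others in the source may bear on it.

Compound 3 `Nc1nonc1C(=O)Nc1cc(C(F)(F)F)cc(C(F)(F)F)c1` gives -9.2% in an assay on isolated protein for inhibition of mitogen-activated protein kinase kinase kinase 14 (Homo sapiens), read by ADP-Glo, with a stated time of 60 min, tested at 100 uM, in the presence of a further agent that is not named here (a higher number here means more inhibition at the concentration tested (going by the name of the read-out), a lower number less inhibition), the lowest of the three numbers. Compound 1 `COc1nsnc1C(=O)Nc1cc(C(F)(F)F)cc(C(F)(F)F)c1` gives -1.9% and compound 2 `Cc1c(C(=O)Nc2cc(C(F)(F)F)cc(C(F)(F)F)c2)c(O)nn1C` gives 24.1%; the step of a number 7.3 percentage points lower from compound 1 to compound 3 (within the scatter) lies within the scatter, whereas a number 33.3 percentage points lower from compound 2 to compound 3 (beyond the scatter) is large. Compound 4 `Cn1nc(O)c(C(=O)Nc2cc(C(F)(F)F)cc(C(F)(F)F)c2)n1` differs from compound 3 in one place: 5-hydroxy-2-methyl-2H-1,2,3-triazol-4-yl in place of 4-amino-1,2,5-oxadiazol-3-yl on a carbonyl carbon. Both steps that change the group on the carbonyl carbon bear on this, and the one that brings in a hydroxy-bearing azole, a number 26 percentage points higher from compound 1 to compound 2 (beyond the scatter), was modest. The 5-hydroxy-2-methyl-2H-1,2,3-triazol-4-yl group of compound 4 is closer in make-up to the 3-hydroxy-1,5-dimethyl-1H-pyrazol-4-yl group of compound 2 than to the 4-amino-1,2,5-oxadiazol-3-yl group of compound 3, so a rise is expected, the step of a number 24.2 percentage points higher from compound 3 to compound 4 (beyond the scatter). Compound 4 is therefore estimated at 15%, with a range from -5% to 35%.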

Compound 4, a percentage reported as inhibition, at one concentration (the size of the read-out at that concentration, not a potency): 9.1%
Compound 4: middle estimate off by 5.9 percentage points, on the high side; the range from low to high includes it.
By their numbers in this assay, from the lowest: compounds 3 and 1 (each within the scatter of the next); then compound 4; then compound 2.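

On the carbonyl carbon, the 5-hydroxy-2-methyl-2H-1,2,3-triazol-4-yl group raises the number in this assay, with a number 18.3 percentage points higher from compound 3 to compound 4 (beyond the scatter) and a number 11 percentage points higher from compound 1 to compound 4 (beyond the scatter), so a second hydroxy-bearing azole also stands above both groups that lack a hydroxy. It still falls short of the 3-hydroxy-1,5-dimethyl-1H-pyrazol-4-yl group, with a number 15 percentage points lower from compound 2 to compound 4 (beyond the scatter), so the hydroxy does not settle the number alone. Nothing measured here explains these differences. The compounds shown do not separate the hydroxy from the ring that carries it. A methoxy or an amine in its place would address that.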